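The source may hold more compounds than are shown below. What is called first, only, known or untested is meant among the compounds shown, and "the series" means these compounds.

Measured so far in an assay on CHO cells for positive allosteric modulation of adenosine receptor A1 (Homo sapiens), read by ERK phosphorylation, tested at 3 uM; a lower number here means a stronger effect, a higher number a weaker effect of the compound at the concentration tested:
compound 1, `Nc1sccc1C(=O)c1ccc(Cl)cc1`, 50%
compound 2, `COc1ccc(-c2cc(C(=O)c3ccccc3)c(N)s2)cc1`, 31%

Of these two numbers, compound 1 has the higher one, which in this assay means the weaker effect at the tested concentration. Compound 2 sits lower, and the gap between them is beyond the usual scatter of such measurements. Nothing more can be said about that pair than what its two values show.

Compound 3, `Nc1sc(-c2ccncc2)cc1C(=O)c1ccc(Cl)cc1`, has not yet been measured. It differs from compound 1 in one place: pyridin-4-yl in place of hydrogen on an aromatic carbon. The shared core and the rest of compound 1 are kept.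

Since compound 2, which also carries an aromatic ring on the core, gives 31%, a step downward, towards a stronger effect, is expected for compound 3, roughly a number 14 percentage points lower from compound 1 to compound 3 (beyond the scatter). The estimated value for compound 3 is 36%, with a likely range from 20% to 55%.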

Compound 3, a percentage reported as activity, at one concentration (the size of the read-out at that concentration, not a potency): 44%
Compound 3: middle estimate off by 8 percentage points, on the low side; low and high end bracket the measured number.
By their numbers in this assay, from the lowest: compound 2; then compounds 3 and 1 (each within the scatter of the next).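

In this assay, placing pyridin-4-yl on the aromatic carbon next to the ring sulfur gives a number 6 percentage points lower from compound 1 to compound 3 (within the scatter), so compound 1 and compound 3 cannot be told apart at the tested concentration. This shows that this position can carry a six-membered aromatic ring with a ring nitrogen, while the effect stays within the scatter of that of the unsubstituted compound 1. No measurement shown here explains this result.

Compound 2 differs from compound 3 in more than one place, so it cannot show how much the ring at this position itself contributes. From the compounds shown here alone, it remains open how this position would respond, with the rest of compound 1 kept, to a plain phenyl ring, a methyl group or a carboxylic acid.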